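This account rests on a few compounds, and the source may have more. Where it says the series, first, only, none or still open, it means among the compounds named here.

Of the compounds shown here, three have been tested so far in a functional assay on the whole organism for agonist activity, with Mus musculus as the target (a higher number here means that more compound is needed for the effect, a lower number that less compound is needed), and a fourth waits its turn. Compound 1 `CC1CCC(=O)N1CC#CCn1ccnc1` carries a 1H-imidazol-1-yl group on a saturated chain carbon bound to a triple-bonded carbon. In this assay compound 1 reaches only a limit, > 100 mg/kg, so no number is known for it; the same holds for (the limit of > 100 mg/kg in this assay, at which 1 of the 3 values shown sits). Compound 2 `CC1CCC(=O)N1CC#CCN(C)C` differs from compound 1 in one place only, (dimethylamino in place of 1H-imidazol-1-yl on a saturated chain carbon bound to a triple-bonded carbon). In this assay compound 2 gives 3 mg/kg, and the step is an at least 33-fold lower number from compound 1 to compound 2 (1.52 log units; beyond the scatter). Compound 3 `COC(=O)N(C)CC#CCn1ccnc1` keeps the 1H-imidazol-1-yl group but sits on another core; how the core of compound 3 differs from the core of compound 1 is not broken down here. In this assay compound 3 gives 4.5 mg/kg, which lies within the scatter of compound 2.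

Compound 4 `COC(=O)N(C)CC#CCN(C)C` is not yet measured. It differs from compound 3 by dimethylamino in place of 1H-imidazol-1-yl on a saturated chain carbon bound to a triple-bonded carbon, the same change, at the same place, that was made from compound 1 to compound 2. Whether that change does as much on the core of compound 3 as it did from compound 1 to compound 2 is not known, and because compound 1 sits at > 100 mg/kg the size of that first step is itself only a lower bound. Starting from compound 3, compound 4 is expected to give 1.5 mg/kg, with a plausible range from 0.3 mg/kg to 6 mg/kg. The step from compound 3 to compound 4 is estimated at a 3.0-fold lower number from compound 3 to compound 4 (0.48 log units; beyond the scatter), a guess that rests on the direction of the change from compound 1 to compound 2, tempered by the fact that compound 3 already gives 4.5 mg/kg.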

Compound 4, dose for half-maximal effect: 14.3 mg/kg
For compound 4 the middle estimate is 9.5-fold (0.98 log units) below the measured one; measured number above the stated range.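

In this assay, putting dimethylamino in place of 1H-imidazol-1-yl on the core of compound 3 gives a 3.2-fold higher number from compound 3 to compound 4 (0.50 log units; beyond the scatter), so the gain seen on the first core does not carry over to this one. Set beside the earlier step, the same change runs in opposite directions on the two cores, and the gap between the steps is larger than measurement scatter can account for: the same change on two cores in this assay, an at least 33-fold lower number (1.52 log units; beyond the scatter) from compound 1 to compound 2 and a 3.2-fold higher number (0.50 log units; beyond the scatter) from compound 3 to compound 4, at least 100-fold (2.02 log units) apart, beyond the scatter of two such steps

Compound 1 gives > 100 mg/kg, which is a limit of the assay and not a number, so the earlier step has a known direction but no exact size. The pair of steps shows that the outcome of this change depends on the core in this series, but it does not show why, and two cores give no basis for a rule that would predict the result on a third.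

Going by these compounds, it remains open whether other amines, such as diethylamino or pyrrolidin-1-yl, would follow dimethylamino on each core, and whether another aromatic ring, such as 1H-pyrazol-1-yl, would follow 1H-imidazol-1-yl. Also open, on these data alone, is whether a longer chain carrying these groups would keep the same reversal from one core to the other.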